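Trimming the propyl chain on the arylamino group

This account rests on a few compounds, and the source may have more. Where it says the series, first, only, none or still open, it means among the compounds named here.

The series shares the core of compound 1 `O=C1CCC(N2C(=O)c3ccc(Nc4ccccn4)cc3C2=O)C(=O)N1` and is read in an assay on FRT-Jurkat cells for inhibition of nuclear factor NF-kappa-B complex (Homo sapiens), read by flow cytometry, with a stated time of 24 h, tested at 10 uM; on this read-out lower numbers stand for less inhibition and higher numbers for more inhibition at the one concentration tested (going by the name of the read-out). Compound 1 gives 9%. Compound 2 `CN(c1ccccc1)c1ccc2c(c1)C(=O)N(C1CCC(=O)NC1=O)C2=O` gives -2%; the step of a number 11 percentage points lower from compound 1 to compound 2 (beyond the scatter) lies beyond the scatter. Compound 3 `CCCc1ccc(Nc2ccc3c(c2)C(=O)N(C2CCC(=O)NC2=O)C3=O)cc1` gives 10%; its number and that of compound 1 sit within the scatter of each other, as the step of a number 1 percentage points higher from compound 1 to compound 3 (within the scatter) shows, while the number of compound 2 lies below it beyond the scatter. Compound 4 `CCc1ccc(Nc2ccc3c(c2)C(=O)N(C2CCC(=O)NC2=O)C3=O)cc1` differs from compound 3 by hydrogen in place of methyl on a saturated chain carbon, two bonds along the chain from an aromatic carbon, that is 4-propylphenyl to 4-ethylphenyl. Among the compounds with values here, no measured step shortens this chain; the nearest guide is the step of a number 1 percentage points higher from compound 1 to compound 3 (within the scatter), where 4-propylphenyl replaced pyridin-2-yl on a nitrogen on an aromatic ring without moving the number beyond the scatter. The expected step is therefore a number 1 percentage points lower from compound 3 to compound 4 (within the scatter), none beyond the scatter. Compound 4 is estimated at 9%, in the range -2% to 20%.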

Compound 4, a percentage reported as inhibition, at one concentration (the size of the read-out at that concentration, not a potency): 5%
For compound 4 the middle estimate is 4 percentage points above the measured one; measured number inside the range.
By their numbers in this assay, from the lowest: compounds 2, 4, 1 and 3 (each within the scatter of the next, the first and the last beyond it).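

Cutting 4-propylphenyl to 4-ethylphenyl gives a number 5 percentage points lower from compound 3 to compound 4 (within the scatter), so on this saturated chain carbon, hydrogen in place of methyl does not separate the two compounds. The swap of pyridin-2-yl for 4-ethylphenyl gives a number 4 percentage points lower from compound 1 to compound 4 (within the scatter), and with a number 7 percentage points higher from compound 2 to compound 4 (within the scatter) compound 4, unlike compounds 1 and 3, stands within the scatter of compound 2. No supporting data on the cause of these steps are available.

On these data alone, whether a longer chain such as butyl, or an amine or carboxylic acid at the chain end, would move the number beyond the scatter stays open.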